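Fluoropyridine swap at the assay limit

The source may hold more compounds than are shown below. What is called first, only, known or untested is meant among the compounds shown, and "the series" means these compounds.

Measured in an ADME assay on HepG2 cells (Homo sapiens) for cytotoxicity, read by resazurin assay, with a stated time of 48 h; on this read-out lower numbers stand for an effect already at smaller amounts and higher numbers for an effect only at larger amounts of compound:
- compound 1 `O=C(Nc1ccc(F)c(-c2nc3ncc(-c4ccc(F)c(F)c4)cc3[nH]2)c1)N1CCCC1` gives > 50000 nM (a limit)
- compound 2 `O=C(Nc1ccc(F)c(-c2nc3ncc(-c4cc(F)ccc4F)cc3[nH]2)c1)N1CCCC1` gives > 50000 nM (a limit)
- compound 3 `Cc1nc(C)c(C(=O)Nc2ccc(F)c(-c3nc4ncc(-c5cccnc5Cl)cn4n3)c2)o1` gives > 50000 nM (a limit)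

Compound 2 has no number of its own in this assay, only a limit. The other two measured compounds give no number either: the limit of > 50000 nM in this assay, at which 3 of the 3 values shown sit.

The next compound to be measured is compound 4 `O=C(Nc1ccc(F)c(-c2nc3ncc(-c4cncc(F)c4)cc3[nH]2)c1)N1CCCC1`, in which 5-fluoropyridin-3-yl takes the place of 2,5-difluorophenyl on an aromatic carbon of the core: 5-fluoropyridin-3-yl in place of 2,5-difluorophenyl on an aromatic carbon.

Going by the values given here, one measured step touches the same place, an exchange of one difluorophenyl group for another: a step that the two limits leave unreadable from compound 1 to compound 2. That step gives no size, as both of its ends are limits. A pyridine in this place has not yet been measured on the core of compound 2. With no readable step to draw on, no step beyond the usual scatter is expected in this assay, and no direction is expected either. The expected step is a step that the limit leaves unreadable from compound 2 to compound 4. The assay will most likely report only a limit again. For compound 4 the estimated value is 60000 nM, with an expected range from 25000 nM to 100000 nM.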

Compound 4, half-maximal effective concentration: > 50000 nM
Compound 4 was reported as a limit (the forecaster's own chance of this, stated with the estimate: 80%); the middle value lies beyond the limit too.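

Compound 4, like compound 1 and compound 2, gives only a limit in this assay, so no step among these three compounds can be read: the limit of > 50000 nM in this assay, at which 4 of the 4 values shown sit.

Still open is whether 5-fluoropyridin-3-yl, 2,5-difluorophenyl and 3,4-difluorophenyl on the shared core differ at all in this assay, and at what concentration any of these compounds would show an effect.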